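The source may hold more compounds than are shown below. What is called first, only, known or untested is meant among the compounds shown, and "the series" means these compounds.

In a functional assay on MCF7 cells (Homo sapiens) for inhibition, read by sulforhodamine B assay, with a stated time of 72 h (a lower number here means a stronger inhibitor of growth, a higher number a weaker inhibitor of growth), compound 2 `CNC(=O)/C=C/c1ccncc1-c1ccc2c(ccn2C)c1` gives 7120 nM. Within the data shown here, this is the only true number available so far, so there is no second measured value to rank it against. Compound 1 `CCOC(=O)/C=C/c1ccncc1-c1ccc2[nH]ccc2c1` reports only a limit of the assay, > 10000 nM, and not a number.

The next compound to be tested, compound 3 `CNC(=O)/C=C/c1ccncc1-c1ccc2[nH]ccc2c1`, differs from compound 2 in one place: hydrogen in place of methyl on an aromatic nitrogen. Among the measured compounds shown here, the change is small, and no pair of measured compounds shows what it does in this assay. With no such guide, no shift beyond the usual scatter is expected, in either direction.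

The expected result is a 1.0-fold lower number from compound 2 to compound 3 (0.01 log units; within the scatter), which would leave the two compounds hard to tell apart. For compound 3 the estimate is 7000 nM, with an expected range from 2500 nM to 10000 nM.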

Compound 3, concentration for 50% growth inhibition: > 10000 nM
Compound 3: no number, only a limit; the forecaster's own chance of this, stated with the estimate: 35%; at least 1.4-fold (0.15 log units) between middle value and limit.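

Among these compounds, on the aromatic nitrogen, hydrogen in place of methyl gives an at least 1.4-fold higher number from compound 2 to compound 3 (0.14 log units; that floor lies within the scatter) in this assay, the first readable step at this position, and it shows no gain in growth inhibition from removing the methyl. The true size of the step stays hidden because compound 3 reports only a limit and not a number: the limit of > 10000 nM in this assay, at which 2 of the 3 values shown sit. The step between compound 1 and compound 3, methylamino in place of ethoxy on a carbonyl carbon, cannot be read, since both of its values are limits.

From the compounds shown here alone, whether the methyl itself matters remains open, since the floor of the step does not clear the usual scatter. Also open, going by these compounds, is what an ethyl group or a longer chain on that aromatic nitrogen would do to growth inhibition.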